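Bromo on the fused ring of a weakly active hydrazone

The source may report more compounds than this note shows. Statements on the series, on what has been measured and on what is new or still open speak of the compounds shown alone.

In a functional assay on MCF7 cells (Homo sapiens) for inhibition, read by MTT assay, with a stated time of 48 h (on this read-out higher numbers stand for weaker inhibition and lower numbers for stronger inhibition), compound 1 `O=C(N/N=C/c1c(-c2cc3ccccc3oc2=O)[nH]c2ccccc12)c1ccccc1Cl` gives 164000 nM. Compound 2 `O=C(N/N=C/c1c(-c2cc3ccccc3oc2=O)[nH]c2ccccc12)c1ccccc1F` is recorded only as a limit of the assay, > 200000 nM. Compound 3 `O=C(N/N=C/c1c(-c2cc3ccccc3oc2=O)[nH]c2ccccc12)c1ccc(Cl)cc1F` likewise sits at a limit, > 200000 nM. The measured steps are small or unreadable: an at least 1.2-fold higher number from compound 1 to compound 2 (0.08 log units; that floor lies within the scatter), an at least 1.2-fold higher number from compound 1 to compound 3 (0.08 log units; that floor lies within the scatter), and a step that the two limits leave unreadable from compound 2 to compound 3, owing to the limit of > 200000 nM in this assay, at which 2 of the 3 values shown sit. Compound 4 `O=C(N/N=C/c1c(-c2cc3ccc(Br)cc3oc2=O)[nH]c2ccccc12)c1ccccc1F` differs from compound 2 by bromo in place of hydrogen on an aromatic carbon. Among the compounds with values here, no measured step touches that place, so the data give no direction for it; with compound 2 already at a limit, compound 4 is expected to remain near the limit as well. Compound 4 is therefore estimated at 200000 nM, ranging from 80000 nM to 400000 nM. This estimate means a number no higher from compound 2 to compound 4 (the limit leaves the size open).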

Compound 4, half-maximal inhibitory concentration: > 200000 nM
Compound 4: only a limit was reported; the forecaster's own chance of this, stated with the estimate: 65%; the middle value sits exactly at the limit.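

Compound 4 is recorded only as a limit of the assay, > 200000 nM, and compound 2 also sits at a limit, so no step between them can be read in this assay: the limit of > 200000 nM in this assay, at which 3 of the 4 values shown sit.

The compounds shown leave open what bromo in place of hydrogen on an aromatic carbon does to the read-out.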